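From amino to dimethylamino on compound 2

The compounds below may be only part of what the source reports. "The series", "measured", "known", "first", "only" and "open" are said of these compounds alone.

Of the compounds shown here, three have so far been measured in a functional assay on HCT-8 cells (Homo sapiens) for antiproliferative activity, read by MTT assay, with a stated time of 48 h (a lower number here means a stronger inhibitor, a higher number a weaker inhibitor), and they do not sit together. Compound 2 (`C=C(c1ccc2c(c1)C=CC(C)(C)O2)c1ccc(OC)cc1NC(=O)CN`) gives 220 nM and compound 3 (`C=C(c1ccc(OC)cc1NC(=O)CNC)c1ccc(OC)c2c1OC(C)(C)C=C2`) gives 320 nM in this test, so the two share the low end of the three numbers, within the scatter of each other. Compound 1 (`CNCC(=O)Nc1cc(OC)ccc1C(=O)c1ccc(OC)c2c1C=CC(C)(C)O2`) gives 3460 nM and lies well beyond the scatter from compound 2. No two of these compounds differ in one place only, so no single change can be read from them directly.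

Compound 4 (`C=C(c1ccc2c(c1)C=CC(C)(C)O2)c1ccc(OC)cc1NC(=O)CN(C)C`) carries dimethylamino in place of amino on a saturated chain carbon bound to a carbonyl carbon and is otherwise the same as compound 2. Among the compounds with values here, the only guide is indirect. The chain end of compound 3 (320 nM) differs from that of compound 2 (220 nM) and the two values stay within the scatter, although these compounds also differ elsewhere. A small rise in this assay is therefore expected, with the estimated step of a 1.4-fold higher number from compound 2 to compound 4 (0.13 log units; within the scatter) remaining within the scatter. For compound 4 the estimated value is 300 nM with an expected range from 100 nM to 900 nM in this test.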

Compound 4, half-maximal inhibitory concentration: 690 nM
Beside the measured number, compound 4's estimate is 2.3-fold (0.36 log units) below it, within the range that was stated.
By their numbers in this assay, from the lowest: compounds 2 and 3 (each within the scatter of the next); then compound 4; then compound 1.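

In this assay, within the data shown here, this is the first change in one place that can be read, and it shows that the position on the saturated chain carbon bound to a carbonyl carbon is not indifferent to what it carries: dimethylamino in place of amino gives a 3.1-fold higher number from compound 2 to compound 4 (0.50 log units; beyond the scatter), a modest step towards weaker inhibition that lies beyond the scatter. The change replaces a group of 1 heavy atom and 1 hydrogen-bond donor with one of 3 heavy atoms and 0 hydrogen-bond donors, while the hydrogen-bond acceptor count stays the same and neither group carries a net charge, and this single pair cannot separate the added heavy atoms from the lost donor. No measurement shown here bears on the reason for the step.

The compounds shown leave open how a cyclic amine such as pyrrolidinyl or a hydroxyl group would read at this same place on the core of compound 2. They also leave open whether the same change from amino to dimethylamino would produce a step of similar size on the core of compound 1 or compound 3.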